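The compounds below may be only part of what the source reports. "The series", "measured", "known", "first", "only" and "open" are said of these compounds alone.

Measured compounds:
compound 1 `CCOc1ccc(-c2cc(=O)c3c(o2)C(CC)(CC)C(=O)C(CC)=C3O)cc1`: 7.54 uM
compound 2 `CCC1=C(O)c2c(oc(-c3cc(C)c(OC)cc3C)cc2=O)C(CC)(CC)C1=O`: 7.58 uM
compound 3 `CCC1=C(O)c2c(oc(-c3ccc(OC)c(OC)c3OC)cc2=O)C(CC)(CC)C1=O`: 1.57 uM

All three values come from a functional assay on KBVIN cells (Homo sapiens) for antiproliferative activity, read by sulforhodamine B assay, with a stated time of 3 days; on this read-out higher numbers stand for an effect only at larger amounts of compound and lower numbers for an effect already at smaller amounts. Compound 1 stands second highest of the three numbers; compound 2 sits at practically the same value, within the scatter, so no order between compound 1 and compound 2 can be read. Compound 3 gives the lowest number, and its gap to compound 1 lies beyond the scatter.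

Compound 4 `CCC1=C(O)c2c(oc(-c3ccc(O)c(O)c3)cc2=O)C(CC)(CC)C1=O` is not yet measured in this assay. It differs from compound 1 as follows: 3,4-dihydroxyphenyl in place of 4-ethoxyphenyl on an aromatic carbon

Within the data shown here, no measured step between two compounds is available, so the size of this change is estimated from the spread of the three values alone. For the step of a 1.3-fold higher number from compound 1 to compound 4 (0.12 log units; within the scatter) a small shift toward a higher number is expected, not clearly beyond the scatter. Compound 4 is expected at 10 uM, with a range from 3 uM to 30 uM.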

Compound 4, concentration for half-maximal effect: 5.41 uM
The estimate for compound 4 lay 1.8-fold (0.27 log units) above the measured number; the measured number falls inside the stated range.
By their numbers in this assay, from the lowest: compound 3; then compounds 4, 1 and 2 (each within the scatter of the next).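

In this assay, 3,4-dihydroxyphenyl in place of 4-ethoxyphenyl, on the aromatic carbon next to the ring oxygen, gives a 1.4-fold lower number from compound 1 to compound 4 (0.14 log units; within the scatter). This first single-place step in the series shows that the position accepts an entering group with two hydrogen-bond donors, where the leaving group has none, with no readable shift in the number. No measurement at hand bears on why the number holds across this exchange.

Open remains whether a phenyl carrying an amine or a carboxylic acid, or a longer chain in place of the ethoxy group, would move the number beyond the scatter at this position.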